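The compounds below may be only part of what the source reports. "The series", "measured", "known", "first", "only" and "open" are said of these compounds alone.

Working notes on the series. For the measured compounds named here, compound 1 `FC(F)(F)c1ccc(CSc2nc(Nc3ccccc3)c3ccccc3n2)cc1` is the parent of the set; in a functional assay on MCF7 cells (Homo sapiens) for cytotoxicity, read by MTT assay, with a stated time of 72 h (a lower number here means a stronger inhibitor, a higher number a weaker inhibitor), compound 1 gives 44000 nM, which is the only numerical value shown among the two measured compounds. Compound 2 `Cc1ccc(Nc2nc(SCc3ccc(C(F)(F)F)cc3)nc3ccccc23)cc1` carries a methyl in place of hydrogen on an aromatic carbon of the same anilino ring. In this assay compound 2 returns > 50000 nM, which is a limit of the assay and not a number (the limit of > 50000 nM in this assay, at which 1 of the 2 values shown sits). The step from compound 1 to compound 2 is therefore only a floor: an at least 1.1-fold higher number from compound 1 to compound 2 (0.05 log units; that floor lies within the scatter).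

Compound 3 `COc1ccc(Nc2nc(SCc3ccc(C(F)(F)F)cc3)nc3ccccc23)c(OC)c1` differs from compound 1 by 2,4-dimethoxyphenyl in place of phenyl on a nitrogen on an aromatic ring. Going by the values given here, the one measured step that bears on it, the methyl addition on the same ring from compound 1 to compound 2, was too small to resolve against a limit, so it gives no direction for a larger substitution on that ring. The expectation for compound 3 is a step close to none beyond the scatter, with a real chance that this assay again reports only a limit: a 1.3-fold higher number from compound 1 to compound 3 (0.10 log units; within the scatter). Compound 3 is thus estimated at 55000 nM, in the range 25000 nM to 120000 nM.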

Compound 3, half-maximal inhibitory concentration: > 50000 nM
Compound 3: a limit, no number; the forecaster's own chance of this, stated with the estimate: 55%; the middle value lies beyond the limit too.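

In this assay compound 3 gives > 50000 nM, which is a limit of the assay and not a number. Even the 2,4-dimethoxyphenyl group, a larger change on this nitrogen than the methyl of compound 2, yields only a floor, an at least 1.1-fold higher number from compound 1 to compound 3 (0.05 log units; that floor lies within the scatter), so neither the direction nor the size of its effect is resolved. The steps that join two limits cannot be read, and both substituted rings shown end at the same ceiling, leaving compound 1 as the only compound with a number: the limit of > 50000 nM in this assay, at which 2 of the 3 values shown sit.

In this assay compound 1 gives 44000 nM. Going by these compounds, it remains open whether a carboxylic acid or a dimethylamino group on this ring would give a readable number there, and whether that number would lie beyond the scatter from the value of compound 1. It also remains open whether changes elsewhere on the shared core, such as a nitrile in place of the trifluoromethyl, would move the series away from the limit, since every change shown here sits on the ring carried by this nitrogen.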